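Phenoxy in Place of Methylsulfanyl: Expected Binding

The source may report more compounds than this note shows. Statements on the series, on what has been measured and on what is new or still open speak of the compounds shown alone.

Compound 1 `CSc1ccc(NC(=O)N[C@@H]2C3CCN(CC3)[C@@H]2Cc2cccnc2)cc1`: in an assay on a protein complex for binding affinity to Neuronal acetylcholine receptor; alpha4/beta2 (Homo sapiens) (a higher number here means a weaker inhibitor, a lower number a stronger inhibitor), compound 1 gives only the assay limit > 10000 nM.
Compound 2 `O=C(Nc1cccc(F)c1)N[C@@H]1C2CCN(CC2)[C@@H]1Cc1cccnc1`: in this assay compound 2 gives only the assay limit > 10000 nM.

Both measured values sit at the limit of this assay (the limit of > 10000 nM in this assay, at which 2 of the 2 values shown sit), so compound 1 stands not at a number but at a limit. The step from compound 1 to compound 2, a step that the two limits leave unreadable from compound 1 to compound 2, cannot be read in size, since both ends are limits. Compound 3 `O=C(Nc1ccc(Oc2ccccc2)cc1)N[C@@H]1C2CCN(CC2)[C@@H]1Cc1cccnc1` differs from compound 1 by phenoxy in place of methylsulfanyl on an aromatic carbon. Among the compounds with values here, no measured step bears on this change with a readable size; the only guide is that both measured compounds of this core reached the limit. The step from compound 1 to compound 3 is therefore expected to be a step that the limit leaves unreadable from compound 1 to compound 3, most likely ending again at a limit. Compound 3 is expected to give about 20000 nM in this assay, within a range from 3000 nM to 100000 nM.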

Compound 3, inhibition constant: > 10000 nM
Compound 3: a limit, no number; the forecaster's own chance of this, stated with the estimate: 75%; the middle value is on the limit's open side.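

Compound 3 also gives only a limit, so the change from compound 1 to compound 3 cannot be read in size: the limit of > 10000 nM in this assay, at which 3 of the 3 values shown sit.

The compounds shown leave open what change to the shared core, if any, would give a measurable number in this assay.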